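Chain growth on the carbonyl: compound 2 to compound 3

A few compounds are considered here, and "the series" means these few. Any claim that something is new, unique, unknown or untested is made for them only; others in the source may bear on it.

Measured in a functional assay on MCF7 cells (Homo sapiens) for antiproliferative activity, read by MTT assay, with a stated time of 72 h; a lower number here means a stronger inhibitor, a higher number a weaker inhibitor:
compound 1 `C=CC(=O)Nc1cccc(Oc2nc(Nc3cccc(OC)c3)nc3c2CSCC3)c1` gives > 50000 nM (a limit)
compound 2 `CC/C=C/C(=O)Nc1cccc(Oc2nc(Nc3cccc(OC)c3)nc3c2CSCC3)c1` gives 24200 nM

Among the measured compounds shown here, compound 2 stands alone as the only firm number so far. The value of compound 1 is a limit. Compound 3 `CCC/C=C/C(=O)Nc1cccc(Oc2nc(Nc3cccc(OC)c3)nc3c2CSCC3)c1` differs from compound 2 by methyl in place of hydrogen on a saturated chain carbon, two bonds along the chain from a double-bonded chain carbon, so that but-1-en-1-yl becomes pent-1-en-1-yl. For the measured compounds named here, one measured step bears on this change, also a lengthening of the group on the carbonyl carbon: an at least 2.0-fold lower number from compound 1 to compound 2 (0.31 log units; beyond the scatter). That single step, with a limit at one end, sets no trend. Resting on it, a further small drop in the number is expected in this assay, though a result within the scatter would not surprise. The estimated step is a 1.3-fold lower number from compound 2 to compound 3 (0.13 log units; within the scatter). For compound 3 the estimated value is 18000 nM, with an expected range of 8000 nM to 45000 nM.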

Compound 3, half-maximal inhibitory concentration: 32000 nM
Compound 3: middle estimate off by 1.8-fold (0.25 log units), on the low side; measured number inside the range.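

In this assay the change from but-1-en-1-yl to pent-1-en-1-yl gives a 1.3-fold higher number from compound 2 to compound 3 (0.12 log units; within the scatter) and so does not separate the two compounds; methyl in place of hydrogen at this saturated chain carbon therefore adds no further measurable gain. Pent-1-en-1-yl in place of vinyl gives an at least 1.5-fold lower number from compound 1 to compound 3 (0.19 log units; that floor lies within the scatter) and, unlike the step to but-1-en-1-yl, does not clear the scatter. Compound 1 holds a limit, so each step from it is only a floor: the limit of > 50000 nM in this assay, at which 1 of the 3 values shown sits.

As far as these compounds go, the true size of the gap from vinyl to either longer group remains open. Also open, from the compounds shown here alone, is whether a longer chain, or an amine or carboxylic acid at the end of the chain, would move the number beyond the scatter.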